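The compounds below may be only part of what the source reports. "The series", "measured", "known", "first", "only" and "open" are said of these compounds alone.

Measured compounds in a functional assay on SH-SY5Y cells (Homo sapiens) for cytotoxicity, read by MTT assay, with stated times of 24 h and 4 h; a higher number here means that more compound is needed for the effect, a lower number that less compound is needed:
compound 1 `COc1cc(CNC(=O)/C=C/c2cccc(O)c2)ccc1OCc1nc(C)c(C)nc1C`, 3680 nM;
compound 2 `COc1ccc(/C=C/C(=O)NCc2ccc(OCc3nc(C)c(C)nc3C)c(OC)c2)cc1O`, 8560 nM;
compound 3 `COc1cccc(/C=C/C(=O)NCc2ccc(OCc3nc(C)c(C)nc3C)c(OC)c2)c1`, 4320 nM.

Compound 3 stands second highest of the three numbers in this assay. Its steps to both neighbours lie within the scatter: a 1.2-fold higher number from compound 1 to compound 3 (0.07 log units; within the scatter) and a 2.0-fold lower number from compound 2 to compound 3 (0.30 log units; within the scatter).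

Compound 4 `COc1cc(CNC(=O)/C=C/c2cccc(OC)c2OC)ccc1OCc1nc(C)c(C)nc1C` differs from compound 3 by methoxy in place of hydrogen on an aromatic carbon. Within the data shown here, the one measured step of the same kind, a methoxy in place of hydrogen on an aromatic carbon, is a 2.3-fold higher number from compound 1 to compound 2 (0.37 log units; beyond the scatter), a modest rise beyond the scatter. Nothing else in the series bears on this change. A rise of similar modest size is therefore expected, a 1.6-fold higher number from compound 3 to compound 4 (0.21 log units; within the scatter), though a step within the scatter cannot be excluded. Compound 4 is estimated at 7000 nM in this assay, with a range from 3000 nM to 16000 nM.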

Compound 4, half-maximal effective concentration: 7150 nM
For compound 4 the middle estimate is 1.0-fold (0.01 log units) below the measured one; the measured number falls inside the stated range.
By their numbers in this assay, from the lowest: compounds 1, 3, 4 and 2 (each within the scatter of the next, the first and the last beyond it).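

In this assay, methoxy in place of hydrogen, here ortho to a methoxy group, gives a 1.7-fold higher number from compound 3 to compound 4 (0.22 log units; within the scatter). With 2,3-dimethoxyphenyl, compound 4 stands apart from neither hydroxylated compound: a 1.2-fold lower number from compound 2 to compound 4 (0.08 log units; within the scatter) and a 1.9-fold higher number from compound 1 to compound 4 (0.29 log units; within the scatter). The change now reads alike on two cores: the same change on two cores in this assay, a 2.3-fold higher number (0.37 log units; beyond the scatter) from compound 1 to compound 2 and a 1.7-fold higher number (0.22 log units; within the scatter) from compound 3 to compound 4, 1.4-fold (0.15 log units) apart, within the scatter of two such steps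

As far as these compounds go, whether an amine or a carboxylic acid on this aromatic carbon would give a step beyond the scatter remains open. So does the effect of a longer chain in place of methoxy.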